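Diethylamino swap on the pyrazin-2-yl compound

The compounds below may be only part of what the source reports. "The series", "measured", "known", "first", "only" and "open" are said of these compounds alone.

Values in a functional assay on U-937 cells (Homo sapiens) for antiproliferative activity, read by CCK-8 assay, with a stated time of 24 h; a higher number here means a weaker inhibitor, a lower number a stronger inhibitor:
- compound 1 `C/C(=N\NC(=O)Nc1nc2ccc(CN(C)C)cc2s1)c1ccccn1`: 20100 nM
- compound 2 `C/C(=N\NC(=O)Nc1nc2ccc(CN(C)C)cc2s1)c1cnccn1`: > 40000 nM (a limit)
- compound 3 `CCN(CC)Cc1ccc2nc(NC(=O)NN=C(c3ccccn3)c3ccccn3)sc2c1`: 9100 nM

Compound 2 gives > 40000 nM, which is a limit and not a number (the limit of > 40000 nM in this assay, at which 1 of the 3 values shown sits). Compound 4 `CCN(CC)Cc1ccc2nc(NC(=O)N/N=C(\C)c3cnccn3)sc2c1` carries diethylamino in place of the dimethylamino of compound 2 on a saturated chain carbon bound to an aromatic carbon (diethylamino in place of dimethylamino on a saturated chain carbon bound to an aromatic carbon). For the measured compounds named here, no measured step covers this change. Going by the values given here, the only measured step, an at least 1.9-fold higher number from compound 1 to compound 2 (0.29 log units; that floor lies within the scatter), concerns pyrazin-2-yl in place of pyridin-2-yl instead. Compound 3 carries diethylamino and gives 9100 nM, but it also differs from compound 1 elsewhere, so it offers only weak support for a modest move towards a lower number in this assay. The expected change is an at least 1.3-fold lower number from compound 2 to compound 4 (0.12 log units; that floor lies within the scatter). Compound 4 is estimated at 30000 nM, with an expected range of 13000 nM to 55000 nM.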

Compound 4, half-maximal inhibitory concentration: > 40000 nM
Compound 4: a limit, no number; the forecaster's own chance of this, stated with the estimate: 40%; at least 1.3-fold (0.12 log units) between middle value and limit.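

Compound 2 and compound 4 both sit at a limit in this assay, so no step between them can be read: the limit of > 40000 nM in this assay, at which 2 of the 4 values shown sit.

From the compounds shown here alone, whether diethylamino in place of dimethylamino changes the antiproliferative reading on this pyrazin-2-yl scaffold stays open.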